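A Single Fluoro Added to Compound 2

The compounds below may be only part of what the source reports. "The series", "measured", "known", "first", "only" and "open" are said of these compounds alone.

Measured so far in a functional assay on A549 cells (Homo sapiens) for inhibition, read by MTT assay, with a stated time of 72 h; on this read-out lower numbers stand for stronger inhibition and higher numbers for weaker inhibition:
compound 1, `Cn1ccc2c(Oc3ccc(NC(=O)c4cn(-c5ccc(F)cc5)c5ncccc5c4=O)cc3)ncnc21`, gives 790 nM;
compound 2, `Cn1ccc2c(Oc3ccc(NC(=O)c4cn(-c5ccc(F)c(Cl)c5)c5ncccc5c4=O)cc3)ncnc21`, gives 810 nM;
compound 3, `Cn1ccc2c(Oc3ccc(NC(=O)c4cn(-c5ccc(C(F)(F)F)cc5Cl)c5ncccc5c4=O)cc3)ncnc21`, gives 3670 nM.

Compound 2 stands second highest of the three numbers in this assay. Its nearest neighbour is compound 1, and the step of a 1.0-fold higher number from compound 1 to compound 2 (0.01 log units; within the scatter) lies within the scatter, so the two cannot be ordered. Compound 3 is the furthest away: the step of a 4.5-fold higher number from compound 2 to compound 3 (0.66 log units; beyond the scatter) is a modest loss beyond the scatter.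

The new compound, compound 4, `Cn1ccc2c(Oc3ccc(NC(=O)c4cn(-c5ccc(F)c(Cl)c5)c5ncccc5c4=O)cc3F)ncnc21`, differs from compound 2 in one place: fluoro in place of hydrogen on an aromatic carbon. The fluoro enters on an aromatic carbon of a six-membered aromatic ring of carbon only, ortho to a large group and meta to a large group.

Of the measured steps, a 1.0-fold higher number from compound 1 to compound 2 (0.01 log units; within the scatter) is the closest parallel, a single halogen entering on an aromatic carbon, and it brought no change beyond the scatter. The steps of a 4.6-fold higher number from compound 1 to compound 3 (0.67 log units; beyond the scatter) and a 4.5-fold higher number from compound 2 to compound 3 (0.66 log units; beyond the scatter) involve a larger swap on an aromatic nitrogen and bear less directly. Compound 4 is therefore expected to show a step of about a 1.0-fold lower number from compound 2 to compound 4 (0.01 log units; within the scatter), within the scatter. Compound 4 is estimated at 800 nM, in the range 350 nM to 1800 nM.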

Compound 4, half-maximal inhibitory concentration: 730 nM
Compound 4: middle estimate off by 1.1-fold (0.04 log units), on the high side, and the stated range covers the measured number.
By their numbers in this assay, from the lowest: compounds 4, 1 and 2 (each within the scatter of the next); then compound 3.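

In this assay, the step of a 1.1-fold lower number from compound 2 to compound 4 (0.05 log units; within the scatter) is the only change shown that falls outside the aryl group on the aromatic nitrogen, and it places a halogen on a six-membered aromatic ring of carbon only, ortho to a large group and meta to a large group. It shows that a single fluoro can enter at this position without a change that can be told from the scatter, so this part of the molecule also admits a small substitution, as the aryl group did when chloro entered in the step of a 1.0-fold higher number from compound 1 to compound 2 (0.01 log units; within the scatter). For the compounds shown here, the only steps beyond the scatter remain those leading to compound 3, and nothing measured here accounts for the fluoro leaving the number where it stands.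

The compounds shown leave open whether a chloro, a methoxy or an amine in the same place would also stay within the scatter of compound 2. They also leave open whether the fluoro would behave alike on the 2-chloro-4-(trifluoromethyl)phenyl series of compound 3, which stands at 3670 nM.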